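This account rests on a few compounds, and the source may have more. Where it says the series, first, only, none or still open, it means among the compounds named here.

Compound 2 `COc1ccc(OC)c(/C=C/C(=O)Nc2cc3c(Nc4ccc(F)c(Cl)c4)ncnc3cc2O[C@H]2CCOC2)c1` was tested in a functional assay on A549 cells (Homo sapiens) for cytotoxicity, read by MTT assay, with a stated time of 72 h (a lower number here means a stronger inhibitor, a higher number a weaker inhibitor), where compound 2 gives 7300 nM. Among the three compounds measured so far, this is the lowest number. Compound 3 `O=C(/C=C/c1ccc([N+](=O)[O-])cc1)Nc1cc2c(Nc3ccc(F)c(Cl)c3)ncnc2cc1O[C@H]1CCOC1` gives 12000 nM in this assay, and compound 1 `COc1ccc(/C=C/C(=O)Nc2cc3c(Nc4ccc(F)c(Cl)c4)ncnc3cc2OC)c(OC)c1` gives 33300 nM. The gap from compound 2 to compound 3 is within the scatter, whereas compound 1 sits beyond the scatter from compound 2.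

Compound 4 `COc1cc(/C=C/C(=O)Nc2cc3c(Nc4ccc(F)c(Cl)c4)ncnc3cc2O[C@H]2CCOC2)cc(OC)c1O` has not yet been measured in this assay. It differs from compound 2 in a single place: 4-hydroxy-3,5-dimethoxyphenyl in place of 2,5-dimethoxyphenyl on a double-bonded chain carbon bound to a double-bonded chain carbon.

Going by the values given here, only one measured step bears on this change: a 1.6-fold higher number from compound 2 to compound 3 (0.22 log units; within the scatter). That step also exchanged the ring on the same double-bonded chain carbon, and it moved the number by less than the scatter. Among the compounds with values here, no measured compound carries the entering 4-hydroxy-3,5-dimethoxyphenyl, so the expectation rests on that single step alone. Compound 4 is therefore expected to give 9000 nM in this assay, with a range from 3500 nM to 25000 nM. The step this estimate implies is a 1.2-fold higher number from compound 2 to compound 4 (0.09 log units; within the scatter), which is expected to stay within the scatter.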

Compound 4, half-maximal inhibitory concentration: 27000 nM
For compound 4 the middle estimate is 3.0-fold (0.48 log units) below the measured one; measured number above the stated range.
By their numbers in this assay, from the lowest: compounds 2 and 3 (each within the scatter of the next); then compounds 4 and 1 (each within the scatter of the next).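

Going by these compounds alone, the ring on this double-bonded chain carbon is not as free to change as the earlier compounds suggested. In this assay, the exchange to 4-hydroxy-3,5-dimethoxyphenyl gives a 3.7-fold higher number from compound 2 to compound 4 (0.57 log units; beyond the scatter), whereas the earlier exchange of this ring gave only a 1.6-fold higher number from compound 2 to compound 3 (0.22 log units; within the scatter). The new ring also separates from the 4-nitrophenyl ring, with a 2.3-fold higher number from compound 3 to compound 4 (0.35 log units; beyond the scatter), so the choice of ring at this place can shift the number beyond the scatter, although the shift remains modest and nothing measured here explains it.

The entering ring brings a hydroxyl, a hydrogen-bond donor that 2,5-dimethoxyphenyl lacks, and it also carries its methoxy groups differently, so the compounds shown leave open which of these differences goes with the higher number; a 4-hydroxyphenyl or a 3,5-dimethoxyphenyl ring on the same carbon would help to separate them. They also leave open how a ring bearing an amine or a carboxylic acid would compare at this place.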